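Taking the isopropyl off compound 3

The source may report more compounds than this note shows. Statements on the series, on what has been measured and on what is new or still open speak of the compounds shown alone.

compound 1 `Cc1c(COc2cccc(OCC3CCOCC3)c2)[nH]c2ccc(C(=O)O)cc2c1=O`: 400 nM
compound 2 `Cc1ccc2[nH]c(COc3cccc(OCC4CCOCC4)c3)c(C)c(=O)c2c1`: 38 nM
compound 3 `CC(C)c1c(COc2cccc(OCC3CCOCC3)c2)[nH]c2ccccc2c1=O`: 54 nM

All three values come from a functional assay on HUVEC cells (Homo sapiens) for inhibition, using NADPH, with a stated time of 2 h; a higher number here means a weaker inhibitor, a lower number a stronger inhibitor. Compound 3 gives 54 nM, which lies within the scatter of the value for compound 2. Compound 1 stands apart from it, beyond the scatter, with the highest number of the three.

The next compound to be measured is compound 4 `O=c1cc(COc2cccc(OCC3CCOCC3)c2)[nH]c2ccccc12`. Its difference from compound 3 is hydrogen in place of isopropyl on an aromatic carbon.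

Among the measured compounds shown here, only one single-change step has been measured, and it is a different change: methyl in place of carboxy on an aromatic carbon, an 11-fold lower number from compound 1 to compound 2 (1.02 log units; beyond the scatter). This large step shows that one substitution can move the number substantially in this assay, but it says nothing directly about losing the isopropyl. For the measured compounds named here, no measured step fixes the direction here, so a modest rise is only a tentative expectation. The estimated step is a 2.4-fold higher number from compound 3 to compound 4 (0.38 log units; beyond the scatter). Compound 4 is expected at about 130 nM, with an estimated range from 35 nM to 500 nM.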

Compound 4, half-maximal inhibitory concentration: 590 nM
The estimate for compound 4 lay 4.5-fold (0.66 log units) below the measured number; measured number outside the range, above it.
By their numbers in this assay, from the lowest: compounds 2 and 3 (each within the scatter of the next); then compounds 1 and 4 (each within the scatter of the next).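

Replacing the isopropyl with hydrogen on this aromatic carbon, two atoms from the ring nitrogen, gives in this assay an 11-fold higher number from compound 3 to compound 4 (1.04 log units; beyond the scatter). Among the compounds shown here, the only earlier step concerned a carboxy group in a different place, so this is the first sign that this position also matters: here, the isopropyl goes with the much lower number. Nothing given here accounts for the size of this step.

Compounds 1 and 2 carry a methyl on this carbon but differ from compound 3 and compound 4 in more than one place, so they do not show how a methyl alone compares with either hydrogen or isopropyl. On these data alone, how an ethyl, a cyclopropyl or an amine on this carbon would compare also remains open.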